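The source may report more compounds than this note shows. Statements on the series, on what has been measured and on what is new or still open speak of the compounds shown alone.

In a functional assay on MCF7 cells (Homo sapiens) for antiproliferative activity, read by MTT assay, with a stated time of 72 h (a lower number here means a stronger inhibitor, a higher number a weaker inhibitor), the measured compounds read as follows:
- compound 1 `COc1cccc(N(C)S(=O)(=O)C2CC3OC2C(c2ccc(NC(=O)CCCCCCC(=O)O)cc2)=C3c2ccc(O)cc2)c1` gives 39400 nM
- compound 2 `CN(c1cccc2ccccc12)S(=O)(=O)C1CC2OC1C(c1ccc(NC(=O)CCCCCCC(=O)O)cc1)=C2c1ccc(O)cc1` gives 14000 nM
- compound 3 `CCN(c1ccc(C)cc1)S(=O)(=O)C1CC2OC1C(c1ccc(NC(=O)CCCCCCC(=O)O)cc1)=C2c1ccc(O)cc1` gives 42300 nM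

Compound 3 shares the weak end of this small set (a 1.1-fold higher number from compound 1 to compound 3 (0.03 log units; within the scatter)) and stands clear of the remaining value (a 3.0-fold higher number from compound 2 to compound 3 (0.48 log units; beyond the scatter)). Compound 4 `CCN(c1ccc(O)cc1)S(=O)(=O)C1CC2OC1C(c1ccc(NC(=O)CCCCCCC(=O)O)cc1)=C2c1ccc(O)cc1` differs from it in one place (hydroxy in place of methyl on an aromatic carbon), with hydroxy in place of methyl on an aromatic carbon, para to a large group. Among the compounds with values here, no measured step makes this exchange. The closest evidence is an exchange of the whole group on the sulfonamide nitrogen, which stayed modest (a 2.8-fold lower number from compound 1 to compound 2 (0.45 log units; beyond the scatter)). In this assay only a small shift toward a lower number is therefore expected, not one beyond the scatter. The expected step is small (a 1.5-fold lower number from compound 3 to compound 4 (0.18 log units; within the scatter)). Compound 4 is expected at 28000 nM and an estimated 12000 nM to 60000 nM is its range.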

Compound 4, half-maximal inhibitory concentration: 46600 nM
Beside the measured number, compound 4's estimate is 1.7-fold (0.22 log units) below it, and the stated range covers the measured number.
By their numbers in this assay, from the lowest: compound 2; then compounds 1, 3 and 4 (each within the scatter of the next).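

In this assay, hydroxy in place of methyl on this aromatic carbon, para to a large group, brings in a hydrogen-bond donor and acceptor without moving the read-out beyond the scatter (a 1.1-fold higher number from compound 3 to compound 4 (0.04 log units; within the scatter)). The ethyl(4-hydroxyphenyl)amino group also stays within the scatter of (3-methoxyphenyl)(methyl)amino (a 1.2-fold higher number from compound 1 to compound 4 (0.07 log units; within the scatter)), while methyl(naphthalen-1-yl)amino remains apart (a 3.3-fold higher number from compound 2 to compound 4 (0.52 log units; beyond the scatter)). No measurement here bears on the reason for these results. Still open, as far as these compounds go, is whether an amine or a carboxylic acid on this aromatic carbon, or a longer chain in place of ethyl on the sulfonamide nitrogen, would separate from compound 3.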